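The Same Swap Repeated on a Second Core

The source may hold more compounds than are shown below. What is called first, only, known or untested is meant among the compounds shown, and "the series" means these compounds.

Four compounds are followed for their effect on Vero cells in an ADME assay on Vero cells (Chlorocebus sabaeus) for cytotoxicity, read by resazurin assay, with a stated time of 2 days; on this read-out lower numbers stand for higher toxicity in this test and higher numbers for lower toxicity in this test. Compound 1 `Cc1ccc(S(=O)(=O)Nc2cccc(/C=C/C(=O)C[C@@H]3OC[C@@H](O)[C@H](O)[C@H]3O)c2)cc1` gives 94700 nM in this assay. Compound 2 `O=C(/C=C/c1cccc(NC(=O)Nc2ccccc2)c1)C[C@@H]1OC[C@@H](O)[C@H](O)[C@H]1O` gives 309000 nM. Compound 3 `CC(=O)OC[C@H]1O[C@@H](CC(=O)/C=C/c2cccc(NC(=O)Nc3ccccc3)c2)[C@@H](OC(C)=O)[C@@H](OC(C)=O)[C@@H]1OC(C)=O` gives 102000 nM; against compound 1 this number lies within the usual scatter, while against compound 2 it is lower by a gap beyond the scatter. Compound 2 and compound 3 differ in more than one place, and the difference between their two cores is not broken down here.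

Compound 1 arises from compound 2 by one change: (4-methylphenyl)sulfonyl in place of phenylcarbamoyl on a nitrogen on an aromatic ring. This change brought a 3.3-fold lower number from compound 2 to compound 1 (0.51 log units; beyond the scatter).

Compound 4 `CC(=O)OC[C@H]1O[C@@H](CC(=O)/C=C/c2cccc(NS(=O)(=O)c3ccc(C)cc3)c2)[C@@H](OC(C)=O)[C@@H](OC(C)=O)[C@@H]1OC(C)=O` has not yet been measured in this assay. It arises from compound 3 by (4-methylphenyl)sulfonyl in place of phenylcarbamoyl on a nitrogen on an aromatic ring, the same change at the same place, now made on the core of compound 3 rather than that of compound 2.

In this assay, going by the values given here, the step is expected to be a 2.9-fold lower number from compound 3 to compound 4 (0.46 log units; beyond the scatter), set beside the earlier step because a 3.3-fold lower number from compound 2 to compound 1 (0.51 log units; beyond the scatter) is the only instance of this change measured so far, and that single instance on a different core leaves the expectation wide. Compound 4 is accordingly estimated at 35000 nM, with a likely range from 12000 nM to 100000 nM.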

Compound 4, half-maximal cytotoxic concentration: 123000 nM
Beside the measured number, compound 4's estimate is 3.5-fold (0.55 log units) below it; measured number outside the range, above it.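

On the core of compound 3, putting (4-methylphenyl)sulfonyl in place of phenylcarbamoyl on a nitrogen on an aromatic ring gave a 1.2-fold higher number from compound 3 to compound 4 (0.08 log units; within the scatter) in this assay, so on this core the two groups cannot be told apart in this test. The two instances of the change do not agree, and the gap between them is larger than repeated measurements would explain: the same change on two cores in this assay, a 3.3-fold lower number (0.51 log units; beyond the scatter) from compound 2 to compound 1 and a 1.2-fold higher number (0.08 log units; within the scatter) from compound 3 to compound 4, 3.9-fold (0.59 log units) apart, beyond the scatter of two such steps This shows that, in this series, the size of the step seen on the core of compound 2 did not carry over to the core of compound 3, so a step measured on one core is a poor guide to the other; it does not show what in the cores produces the disagreement, nor which of the two steps is the more typical, as each core supplies a single pair.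

The compounds shown leave open how the change behaves on any third core, and whether a further pair on these two cores would repeat the same disagreement. They also leave open whether a smaller group on the same nitrogen, such as methanesulfonyl or benzoyl, would track the core in the same way.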